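Demethylation of the methylsulfanyl group in compound 1

The compounds below may be only part of what the source reports. "The series", "measured", "known", "first", "only" and "open" are said of these compounds alone.

Measured compounds:
Compound 1 `COCc1ncc2cnnc(SC)n12`, reported only as a limit in a functional assay for inhibition, with Homo sapiens as the target; a higher number here means a weaker inhibitor, a lower number a stronger inhibitor: > 48000 nM
Compound 2 `Cc1nc(C)n2c(Nc3cc[nH]n3)nccc12`, in this assay: 53000 nM

Compound 1 stands at the limit of this assay; nothing more than that limit is known for it, as the limit of > 48000 nM in this assay, at which 1 of the 2 values shown sits, records. Compound 2 gives a number rather than a limit in this assay, and that number sits at the weak end of the scale as well. Compound 3 `COCc1ncc2cnnc(S)n12` differs from compound 1 by hydrogen in place of methyl on a sulfur. Within the data shown here, no measured pair shows the effect of such a change, so the direction of the step cannot be read from the numbers. In this assay compound 3 is expected to remain weak, with a step that the limit leaves unreadable from compound 1 to compound 3 not going beyond the scatter. Compound 3 is estimated at 50000 nM, within 15000 nM to 150000 nM.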

Compound 3, half-maximal inhibitory concentration: > 48000 nM
Compound 3: only a limit was reported; the forecaster's own chance of this, stated with the estimate: 60%; the middle value does not contradict the limit.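

Compound 1 and compound 3 are both reported only as limits in this assay, so no step can be read from this pair: the limit of > 48000 nM in this assay, at which 2 of the 3 values shown sit.

The compounds shown leave open whether hydrogen in place of methyl on a sulfur changes inhibition at all, and in which direction.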